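Chain length and two double bonds on the ether side chain

This account rests on a few compounds, and the source may have more. Where it says the series, first, only, none or still open, it means among the compounds named here.

Measured so far:
compound 1 `CCCCCCCCCCCOc1cccc(C(SCCC(=O)O)SCCC(=O)O)c1` gives 78 nM
compound 2 `CCCCCCCCCOc1cccc(C(SCCC(=O)O)SCCC(=O)O)c1` gives 624 nM

Both were tested in an assay on membranes from lung (Cavia porcellus) for binding affinity to cysteinyl leukotriene receptor (Homo sapiens); a higher number here means a weaker inhibitor, a lower number a stronger inhibitor. Among the compounds with values here, compound 2 holds the highest of the two numbers, the only neighbour being compound 1, which lies an 8.0-fold higher number from compound 1 to compound 2 (0.90 log units; beyond the scatter). Within the data shown here, that single step, shortening of the ether chain, is the only measured change available here.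

Compound 3 `CCCCC/C=C/C/C=C/COc1cccc(C(SCCC(=O)O)SCCC(=O)O)c1` is not yet measured. It differs from compound 2 by deca-1,4-dien-1-yl in place of octyl on a saturated chain carbon bound to an oxygen on an aromatic ring. The entering group is longer than the octyl it replaces and carries two double bonds, so the chain end reaches out roughly as far as in compound 1. The step from compound 1 to compound 2 bears on this: taking carbon off the chain gave a clearly higher number, so putting carbon back is expected to lower it again, with the double bonds an unknown. Compound 3 is therefore expected to move a 5.2-fold lower number from compound 2 to compound 3 (0.72 log units; beyond the scatter), to an estimated 120 nM with a range from 30 nM to 500 nM.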

Compound 3, inhibition constant: 187 nM
Compound 3: the middle estimate sits 1.6-fold (0.19 log units) below what was measured, within the range that was stated.
By their numbers in this assay, from the lowest: compound 1; then compound 3; then compound 2.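

In this assay the saturated chain carbon bound to an oxygen on an aromatic ring also accepts an unsaturated chain: deca-1,4-dien-1-yl in place of octyl gives a gain (a 3.3-fold lower number from compound 2 to compound 3 (0.52 log units; beyond the scatter)), so length can be restored without keeping the chain fully saturated. The gain is only partial, since deca-1,4-dien-1-yl in place of decyl leaves a loss beyond the scatter (a 2.4-fold higher number from compound 1 to compound 3 (0.38 log units; beyond the scatter)), which shows that the two chains are not interchangeable at this place. Nothing available accounts for this difference between the two chains.

With a single unsaturated chain in hand, the contribution of each double bond cannot be separated, and a chain with only one double bond would be needed for that. From the compounds shown here alone, it also remains open whether a longer chain such as dodecyl, or a phenyl ring at the chain end, would lower the number further.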